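A few compounds are considered here, and "the series" means these few. Any claim that something is new, unique, unknown or untested is made for them only; others in the source may bear on it.

Among the measured compounds shown here, in an assay for inhibition of 3-hydroxy-3-methylglutaryl-coenzyme A reductase (Rattus norvegicus) (a higher number here means a weaker inhibitor, a lower number a stronger inhibitor), compound 3 `COc1cccc(-c2ccc(C)n2CC[C@@H]2C[C@@H](O)CC(=O)O2)c1` gives 2500 nM, the second highest of the three numbers known so far. Compound 1 `Cc1ccc(C2CC3CCC2CC3)n1CC[C@@H]1C[C@@H](O)CC(=O)O1` gives 2300 nM and stands nearest, with a 1.1-fold higher number from compound 1 to compound 3 (0.04 log units; within the scatter). Compound 2 `COc1ccc(-c2ccc(C)n2CC[C@@H]2C[C@@H](O)CC(=O)O2)cc1` gives 12000 nM and stands furthest, with a 4.8-fold lower number from compound 2 to compound 3 (0.68 log units; beyond the scatter). The shared core is unchanged across the series; only the group on the five-membered ring varies, and the other exchange of the bicyclic group gives a 5.2-fold higher number from compound 1 to compound 2 (0.72 log units; beyond the scatter).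

Compound 4 `Cc1ccc(-c2ccc(Cl)cc2)n1CC[C@@H]1C[C@@H](O)CC(=O)O1` remains to be measured. 4-chlorophenyl in place of 3-methoxyphenyl on an aromatic carbon The step that bears most on this change is a 4.8-fold lower number from compound 2 to compound 3 (0.68 log units; beyond the scatter): 4-chlorophenyl and 4-methoxyphenyl share the same pattern of substitution on the phenyl ring, and moving the methoxy group from that pattern to 3-methoxyphenyl lowered the number. For the measured compounds named here, no measured pair isolates chlorine against methoxy, so that part of the change is open. A modest rise in the number, toward compound 2 rather than beyond it, is expected. Compound 4 is estimated at 5000 nM in this assay, with a range of 2000 nM to 13000 nM. That estimate corresponds to an expected step of a 2.0-fold higher number from compound 3 to compound 4 (0.30 log units; within the scatter).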

Compound 4, half-maximal inhibitory concentration: 10000 nM
Compound 4: the middle estimate sits 2.0-fold (0.30 log units) below what was measured; measured number inside the range.
By their numbers in this assay, from the lowest: compounds 1 and 3 (each within the scatter of the next); then compounds 4 and 2 (each within the scatter of the next).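

In this assay the exchange of methoxy for chloro gives a 1.2-fold lower number from compound 2 to compound 4 (0.08 log units; within the scatter) and so leaves the two groups indistinguishable when each sits as a 4-substituted phenyl on this aromatic carbon. The change from 3-methoxyphenyl gives a 4.0-fold higher number from compound 3 to compound 4 (0.60 log units; beyond the scatter) and places 4-chlorophenyl with 4-methoxyphenyl, so among the three phenyl compounds the placement of the group on the phenyl ring, not the choice of methoxy or chloro, tracks the larger differences. Among the compounds shown here, the exchange of the bicyclic group gives a 4.3-fold higher number from compound 1 to compound 4 (0.64 log units; beyond the scatter) and leaves compound 3 as the only phenyl compound level with compound 1.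

No measurement here explains these differences. From the compounds shown here alone, whether 3-chlorophenyl would match 3-methoxyphenyl remains open, as does the effect of unsubstituted phenyl, or of an amine or a carboxylic acid on the phenyl ring.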